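Dibromophenyl to Methoxy-Methylphenyl at Low Inhibition

A few compounds are considered here, and "the series" means these few. Any claim that something is new, unique, unknown or untested is made for them only; others in the source may bear on it.

Three compounds share one core. Compound 1 `CCCCN(CC)c1cc(C)nc2c1NC(=O)CN2c1ccc(Br)cc1Cl` carries no reported result: in an assay on HEK-293T cells for displacement of a labelled ligand from corticotropin-releasing factor receptor 2 (Homo sapiens), read by scintillation counting, with a stated time of 2 h, tested at 1 uM (on this read-out higher numbers stand for more inhibition at the one concentration tested (going by the name of the read-out) and lower numbers for less inhibition), compound 1 gives "not determined" (no result reported). Compound 2 `CCCCN(CC)c1cc(C)nc2c1NC(=O)CN2c1ccc(C)cc1Cl` is in the same position: in this assay compound 2 gives "not determined" (no result reported). Within the data shown here, compound 3 `CCCCN(CC)c1cc(C)nc2c1NC(=O)CN2c1ccc(Br)cc1Br` is the only one with a number: in this assay compound 3 gives 9.4%, a low level of displacement at the single concentration. Compound 3 thus stands alone as the sole reference, with no second value to set it against.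

Compound 4 `CCCCN(CC)c1cc(C)nc2c1NC(=O)CN2c1ccc(OC)cc1C` differs from compound 3 in one place: 4-methoxy-2-methylphenyl in place of 2,4-dibromophenyl on a nitrogen on an aromatic ring in a ring. Among the measured compounds shown here, no step between two measured compounds exists, so the size of this change has no precedent here. With a single low reference and a swap of one aryl group for another on the same ring nitrogen, the step in this assay is expected to be small, in either direction, and most likely not beyond the usual scatter. Compound 4 is therefore expected to give about 12% in this assay, within a range from 0% to 40%. The expected step is a number 2.6 percentage points higher from compound 3 to compound 4 (within the scatter).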

Compound 4, a percentage reported as inhibition, at one concentration (the size of the read-out at that concentration, not a potency): -2.3%
Estimate against measurement, compound 4: 14.3 percentage points above; measured number below the stated range.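

The swap of 2,4-dibromophenyl for 4-methoxy-2-methylphenyl on the ring nitrogen gives the series its first readable step in this assay, a number 11.7 percentage points lower from compound 3 to compound 4 (beyond the scatter), so the aryl group at this place can shift the read-out beyond the scatter. The shift lies at the low end of the scale, where compound 3 gives 9.4% and compound 4 gives -2.3%, and neither compound shows more than low inhibition at the one concentration tested. Nothing at hand accounts for this step.

Steps involving compound 1 and compound 2 cannot be read, and with both ring substituents changed at once, the share of each in the step remains unknown. Also open, going by these compounds, is whether an aryl group carrying an amine or a carboxylic acid would raise the inhibition at this place.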